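The source may report more compounds than this note shows. Statements on the series, on what has been measured and on what is new or still open speak of the compounds shown alone.

Measured so far:
compound 1 `COc1cc(OC)c(C(=O)/C=C/c2ccccc2SC)c(OC)c1` — 36%
compound 2 `COc1cccc(/C=C/C(=O)c2c(OC)cc(OC)cc2OC)c1` — 31%
compound 3 `COc1cc(O)c(C(=O)/C=C/c2ccccc2SC)c(OC)c1` — 50%

All three numbers come from a functional assay on Caco-2 cells (Homo sapiens), read by fluorescence and BrdU incorporation, with a stated time of 48 h, tested at 10 uM; on this read-out lower numbers stand for a stronger effect and higher numbers for a weaker effect at the one concentration tested. Compound 1 and compound 2 carry different groups on the chain: 3-methoxyphenyl in place of 2-(methylsulfanyl)phenyl on a double-bonded chain carbon bound to a double-bonded chain carbon. The step is a number 5 percentage points lower from compound 1 to compound 2 (within the scatter). Compound 3 arises from compound 1 by hydrogen in place of methyl on an oxygen on an aromatic ring, and this gives a number 14 percentage points higher from compound 1 to compound 3 (beyond the scatter).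

Compound 4 `COc1cccc(/C=C/C(=O)c2c(O)cc(OC)cc2OC)c1` has not yet been measured in this assay. It arises from compound 2 by hydrogen in place of methyl on an oxygen on an aromatic ring, the same change as that from compound 1 to compound 3, at a place described in the same words. Going by the values given here, only that one earlier instance is available, so the expectation rests on compound 3 giving 50% after the same change; the step expected is a number 14 percentage points higher from compound 2 to compound 4 (beyond the scatter). For compound 4 the estimated value is 45%, with an expected range from 33% to 57%.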

Compound 4, a percentage reported as activity, at one concentration (the size of the read-out at that concentration, not a potency): 31%
Compound 4: middle estimate off by 14 percentage points, on the high side; the whole stated range lies above it.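

In this assay, the step from methoxy to hydroxy on the second core reads: no change at the digits printed from compound 2 to compound 4 (within the scatter). Set beside the earlier instance, this does not establish that the outcome of the change depends on the core: the same change on two cores in this assay, a number 14 percentage points higher (beyond the scatter) from compound 1 to compound 3 and no change at the digits printed (within the scatter) from compound 2 to compound 4, 14 percentage points apart, within the scatter of two such steps. Two instances neither fix a size for the change nor show that it carries over unchanged, so no reliable transfer to a further core follows from them.

The compounds shown leave open how this oxygen position would respond to a different group, such as an amine or a longer ethoxy chain. Also open, on these data alone, is whether the change behaves alike with a carboxylic acid on the phenyl ring of the chain.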